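Series notes: removing the ring methyl from compound 3

This account rests on a few compounds, and the source may have more. Where it says the series, first, only, none or still open, it means among the compounds named here.

Measured so far:
- compound 1 `Cc1cccc(/C(N)=N/NC(=S)N2CCN(c3ccccn3)CC2)n1`, 83.8% in a functional assay on A-375 cells (Homo sapiens) for cytotoxicity, read by MTT assay, with a stated time of 72 h, tested at 100 uM; on this read-out higher numbers stand for more inhibition of growth at the one concentration tested and lower numbers for less inhibition of growth
- compound 2 `N/C(=N\NC(=S)N1CCN(c2ccccn2)CC1)c1ccc(F)cn1`, 76.2% in this assay
- compound 3 `Cc1cccc(/C(N)=N/NC(=S)N2CCSCC2)n1`, 77.4% in this assay

Compound 3 stands second highest of the three numbers; compound 2 is nearest and compound 1 furthest, and both gaps to compound 3 lie within the scatter. Compound 4 `N/C(=N\NC(=S)N1CCSCC1)c1ccccn1` differs from compound 3 by hydrogen in place of methyl on an aromatic carbon. Within the data shown here, the only measured step, a number 7.6 percentage points lower from compound 1 to compound 2 (within the scatter), changes the substituent pattern on the same ring and was within the scatter; no measured step removes the methyl itself. No step beyond the scatter is therefore expected in this assay. Compound 4 is estimated at 75% (range 62% to 86%), which means an expected step of a number 2.4 percentage points lower from compound 3 to compound 4 (within the scatter).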

Compound 4, percent growth inhibition at one concentration: 87.8%
Estimate against measurement, compound 4: 12.8 percentage points below; the whole stated range lies below it.
By their numbers in this assay, from the lowest: compounds 2, 3, 1 and 4 (each within the scatter of the next, the first and the last beyond it).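

Hydrogen in place of methyl next to the ring nitrogen gives the first step in the series beyond the scatter in this assay: a number 10.4 percentage points higher from compound 3 to compound 4 (beyond the scatter). The methyl at this place is therefore not required for growth inhibition at the one concentration tested, and its loss does not lower the number here. Nothing available explains this gain.

On these data alone, it remains open whether the same replacement also raises the number on the core of compound 1. Also open, as far as these compounds go, is how a methoxy group, a chlorine atom or an amine at this place would compare with hydrogen.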